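This account rests on a few compounds, and the source may have more. Where it says the series, first, only, none or still open, it means among the compounds named here.

In a functional assay on HT-29 cells (Homo sapiens) for inhibition, read by MTT assay, with a stated time of 2 days (a lower number here means a stronger inhibitor, a higher number a weaker inhibitor), compound 1 `Oc1cccc(/C=C/c2ccccc2O)c1` gives 27 ug/mL, and compound 2 `Nc1cccc(/C=C/c2ccccc2O)c1` gives 30.4 ug/mL. The change between them, (amino in place of hydroxy on an aromatic carbon), made a step of a 1.1-fold higher number from compound 1 to compound 2 (0.05 log units; within the scatter). Compound 3 `COc1ccc(/C=C/c2ccccc2O)cc1` gives 10 ug/mL; the difference between its core and the core of compound 1 is not broken down here. Compound 4 `COc1ccc(/C=C/c2ccccc2N)cc1` has not yet been measured. It differs from compound 3 by amino in place of hydroxy on an aromatic carbon, the same kind of change as between compound 1 and compound 2, though not the same: in the earlier pair the changed carbon is meta to a group of 9 heavy atoms, while here it is ortho to a large group. Since the earlier step of a 1.1-fold higher number from compound 1 to compound 2 (0.05 log units; within the scatter) stayed within the scatter, a similar step, estimated at a 1.2-fold higher number from compound 3 to compound 4 (0.08 log units; within the scatter), is expected. Compound 4 is therefore expected to give about 12 ug/mL, with a likely range from 6 ug/mL to 25 ug/mL.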

Compound 4, half-maximal inhibitory concentration: 73 ug/mL
Estimate against measurement, compound 4: 6.1-fold (0.78 log units) below, outside the stated range (above it).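

In this assay, putting amino in place of hydroxy on the core of compound 3 gave a step of a 7.3-fold higher number from compound 3 to compound 4 (0.86 log units; beyond the scatter), a clear loss of strength as an inhibitor. The same change therefore does not carry over unchanged from one core to another in this series: the same change on two cores in this assay, a 1.1-fold higher number (0.05 log units; within the scatter) from compound 1 to compound 2 and a 7.3-fold higher number (0.86 log units; beyond the scatter) from compound 3 to compound 4, 6.5-fold (0.81 log units) apart, beyond the scatter of two such steps

Within the data shown here, with only two pairs, this does not show which feature of the two cores sets the size of the step, and it gives no rule for a third core.

The compounds shown leave open how a carboxylic acid or a fluorine atom in place of the hydroxy would behave on either core. They also leave open whether a longer chain in place of the methoxy group of compound 3 would alter the step.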